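The source may hold more compounds than are shown below. What is called first, only, known or untested is meant among the compounds shown, and "the series" means these compounds.

Compound 1, with the structure `CC(C)[C@H](NC(=O)COc1cccc2ccccc12)C(=O)N[C@@H](CC(=O)O)C(=O)CSc1nnnn1C`, gives in a functional assay on Jurkat cells (Homo sapiens) for inhibition (a lower number here means a stronger inhibitor, a higher number a weaker inhibitor), the value > 200000 nM. Compound 2, with the structure `CC(C)[C@H](NC(=O)COc1cccc2ccccc12)C(=O)N[C@@H](CC(=O)O)C(=O)COc1cc(C(F)(F)F)ncn1`, gives in this assay the value > 200000 nM.

The value for compound 2 is a limit of the assay and not a number. The same holds for compound 1, whose value is also a limit. Both compounds therefore sit at the limit of > 200000 nM in this assay, at which 2 of the 2 values shown sit, and nothing more is known of where compound 2 actually stands.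

Compound 3, with the structure `CC(C)[C@H](NC(=O)COc1cccc2ccccc12)C(=O)N[C@@H](CC(=O)O)C(=O)COc1nccc(C(F)(F)F)n1`, differs from compound 2 by 4-(trifluoromethyl)pyrimidin-2-yl in place of 6-(trifluoromethyl)pyrimidin-4-yl on an oxygen on a saturated carbon. For the measured compounds named here, the only measured step available, a step that the two limits leave unreadable from compound 1 to compound 2, is unreadable, as both its ends are limits, so no measured step tells how a change at this position moves the read-out in this assay. With both neighbours of compound 3 at the limit, the plain expectation is that compound 3 will most likely again give only a limit in this assay.

The estimate for compound 3 in this assay is 250000 nM, with a range from 80000 nM to 1000000 nM. The step this estimate implies, a step that the limit leaves unreadable from compound 2 to compound 3, is expected to lie within the scatter.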

Compound 3, half-maximal inhibitory concentration: > 200000 nM
Compound 3 gave a limit, no number (the forecaster's own chance of this, stated with the estimate: 85%); the middle value does not contradict the limit.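

Compound 3 gives > 200000 nM in this assay, which is a limit and not a number. No step among compound 1, compound 2 and compound 3 can be read, as all three sit at one limit: the limit of > 200000 nM in this assay, at which 3 of the 3 values shown sit.

The compounds shown leave open how strongly each one inhibits, and whether exchanging the pyrimidine groups changes this at all.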